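The source may hold more compounds than are shown below. What is called first, only, known or untested is meant among the compounds shown, and "the series" means these compounds.

Compound 2 `COc1cc2c(Oc3ccc(NC(=O)c4cn(-c5ccccc5C)nn4)cc3F)ccnc2cc1OCCCN1CCC(C)CC1` carries a 2-methylphenyl group at one end of the shared core. Going by the values given here, in a functional assay on A549 cells (Homo sapiens) for cytotoxicity, read by MTT assay, with a stated time of 72 h (on this read-out higher numbers stand for weaker inhibition and lower numbers for stronger inhibition), compound 2 gives 3500 nM, the highest of the two numbers measured so far. Its nearest neighbour is compound 1 `COc1cc2c(Oc3ccc(NC(=O)c4cn(-c5ccccc5Cl)nn4)cc3F)ccnc2cc1OCCCN1CCC(C)CC1`, which in this assay gives 370 nM; a 9.5-fold higher number from compound 1 to compound 2 (0.98 log units; beyond the scatter). Compound 3 `COc1cc2c(Oc3ccc(NC(=O)c4cn(-c5c(C)cccc5C)nn4)cc3F)ccnc2cc1OCCCN1CCC(C)CC1` differs from compound 2 by methyl in place of hydrogen on an aromatic carbon, so that the 2-methylphenyl becomes a 2,6-dimethylphenyl. Among the compounds with values here, no measured step adds a methyl to this ring; the only measured step, a 9.5-fold higher number from compound 1 to compound 2 (0.98 log units; beyond the scatter), exchanges one group for another and does not bear directly on adding a second one. With nothing in the data pointing clearly one way or the other, the expectation is that a 1.2-fold lower number from compound 2 to compound 3 (0.07 log units; within the scatter), no step beyond the scatter, though with wide uncertainty. Compound 3 is therefore estimated at 3000 nM in this assay, with a range from 700 nM to 13000 nM.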

Compound 3, half-maximal inhibitory concentration: 3340 nM
The estimate for compound 3 lay 1.1-fold (0.05 log units) below the measured number, and the stated range covers the measured number.
By their numbers in this assay, from the lowest: compound 1; then compounds 3 and 2 (each within the scatter of the next).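

In this assay, a 1.0-fold lower number from compound 2 to compound 3 (0.02 log units; within the scatter) is all that the second methyl brings, so the 2-methylphenyl and the 2,6-dimethylphenyl cannot be told apart on this read-out. The 2-chlorophenyl stays clearly separate from the new group too, with a 9.0-fold higher number from compound 1 to compound 3 (0.96 log units; beyond the scatter) as the step, so among these three compounds the lower number goes with the chloro compound, and adding a methyl to the ring does not close the gap. Nothing measured here gives a reason for either result.

As far as these compounds go, it remains open whether a second chloro, as in a 2,6-dichlorophenyl, would keep or lower the number seen with compound 1. From the compounds shown here alone, it is also open whether a fluoro, a methoxy or an amine at this place would read like the chloro compound or like the methyl compounds.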